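Chloro for trifluoromethyl: the step to compound 4

This account rests on a few compounds, and the source may have more. Where it says the series, first, only, none or still open, it means among the compounds named here.

In a functional assay on SNB-75 cells (Homo sapiens) for inhibition, read by sulforhodamine B assay, with a stated time of 48 h, tested at 100 uM (on this read-out higher numbers stand for a weaker effect at the one concentration tested and lower numbers for a stronger effect), compound 3 `COc1cc(Cl)cc(-c2nn(-c3cccc(NC(=O)Nc4ccc(Cl)c(C(F)(F)F)c4)c3)cc2-c2ccncc2)c1` gives -38%, the second highest of the three numbers recorded; its nearest neighbour is compound 1 `O=C(Nc1cccc(-n2cc(-c3ccncc3)c(-c3cc(O)cc(Cl)c3)n2)c1)Nc1ccc(Cl)c(C(F)(F)F)c1` with -41%, the two lying within the scatter, while compound 2 `O=C(Nc1cccc(-n2cc(-c3ccncc3)c(-c3cc(O)cc(Cl)c3)n2)c1)Nc1ccc(Cl)c(Cl)c1` with -15% lies beyond it. Compound 4 `COc1cc(Cl)cc(-c2nn(-c3cccc(NC(=O)Nc4ccc(Cl)c(Cl)c4)c3)cc2-c2ccncc2)c1` has not been measured. It differs from compound 3 in one place: chloro in place of trifluoromethyl on an aromatic carbon. The same exchange has been observed once already, between compound 1 and compound 2, which carry hydrogen instead of methyl on the oxygen: a number 26 percentage points higher from compound 1 to compound 2 (beyond the scatter). The methyl itself changes little, as a number 3 percentage points higher from compound 1 to compound 3 (within the scatter) shows. For the measured compounds named here, the single relevant precedent therefore points to a step of similar size and the same direction for compound 4, beyond the scatter, towards a weaker effect at the concentration tested. Compound 4 is accordingly expected to give -12% in this assay, within a range of -32% to 8%. The expected step is thus a number 26 percentage points higher from compound 3 to compound 4 (beyond the scatter).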

Compound 4, a percentage reported as activity, at one concentration (the size of the read-out at that concentration, not a potency): -3%
Beside the measured number, compound 4's estimate is 9 percentage points below it; low and high end bracket the measured number.
By their numbers in this assay, from the lowest: compounds 1 and 3 (each within the scatter of the next); then compound 2; then compound 4.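

In this assay, the change from 4-chloro-3-(trifluoromethyl)phenyl to 3,4-dichlorophenyl now stands on two cores and goes in the same direction on both, so the first step was not peculiar to the core of compound 1: the same change on two cores in this assay, a number 26 percentage points higher (beyond the scatter) from compound 1 to compound 2 and a number 35 percentage points higher (beyond the scatter) from compound 3 to compound 4, 9 percentage points apart, within the scatter of two such steps. On the core that carries methyl on the oxygen, this change gives a number 35 percentage points higher from compound 3 to compound 4 (beyond the scatter). With 3,4-dichlorophenyl in place, methyl instead of hydrogen on the oxygen gives a number 12 percentage points higher from compound 2 to compound 4 (beyond the scatter), a step beyond the scatter that the trifluoromethyl pair did not show, yet the two methyl steps do not separate: the same change on two cores in this assay, a number 3 percentage points higher (within the scatter) from compound 1 to compound 3 and a number 12 percentage points higher (beyond the scatter) from compound 2 to compound 4, 9 percentage points apart, within the scatter of two such steps.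

Going by these compounds, whether bromo, methyl or nitrile at this position would follow chloro or trifluoromethyl remains open. On these data alone, whether an amine in place of the hydroxyl or methoxy group would preserve the same order also remains open.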